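This account rests on a few compounds, and the source may have more. Where it says the series, first, only, none or still open, it means among the compounds named here.

In a functional assay on DU-145 cells (Homo sapiens) for cytotoxicity, read by ELISA, with a stated time of 4 days (a higher number here means a weaker inhibitor, a lower number a stronger inhibitor), compound 1 (`Cc1ccsc1-c1cc(-c2ccco2)cc(-c2ccccc2Cl)n1`) gives 29900 nM, compound 2 (`Cc1ccsc1-c1cc(-c2ccco2)cc(-c2ccc(Cl)cc2)n1`) gives 26700 nM and compound 3 (`Cc1ccc(-c2cc(-c3ccoc3)cc(-c3ccc(Cl)s3)n2)o1`) gives 33400 nM. These three numbers lie within the scatter of one another, so compound 3 cannot be set apart from the other two.

Compound 4 (`Clc1ccc(-c2cc(-c3ccoc3)cc(-c3ccc(Cl)s3)n2)cc1`) differs from compound 3 in one place: 4-chlorophenyl in place of 5-methylfuran-2-yl on an aromatic carbon. The new 4-chlorophenyl sits next to the ring nitrogen, meta to a 5-chlorothiophen-2-yl group.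

Within the data shown here, the only measured step involving this group is a 1.1-fold lower number from compound 1 to compound 2 (0.05 log units; within the scatter), which lies within the scatter. It exchanges 2-chlorophenyl for 4-chlorophenyl and so bears only indirectly on the change. Among the measured compounds shown here, no measured step exchanges 5-methylfuran-2-yl for 4-chlorophenyl, which leaves the estimate resting on the narrow spread of the three values.

No shift beyond the scatter is therefore expected in this assay, and the estimated step is a 1.2-fold lower number from compound 3 to compound 4 (0.08 log units; within the scatter). Compound 4 is estimated at 28000 nM, with an expected range of 12000 nM to 55000 nM.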

Compound 4, half-maximal inhibitory concentration: 29500 nM
Estimate against measurement, compound 4: 1.1-fold (0.02 log units) below; measured number inside the range.
By their numbers in this assay, from the lowest: compounds 2, 4, 1 and 3 (each within the scatter of the next).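

In this assay, the place next to the ring nitrogen takes 4-chlorophenyl in place of 5-methylfuran-2-yl with a step of a 1.1-fold lower number from compound 3 to compound 4 (0.05 log units; within the scatter) and nothing more. This step is a direct reading at this place: a five-membered aromatic ring with 1 hetero atom gives way to a six-membered aromatic ring of carbon only, and the hydrogen-bond acceptor counted on the leaving group goes without a shift beyond the scatter. No supporting measurement bears on why the number holds across this exchange.

The compounds shown carry only aromatic rings on the shared core, so the reach of this place remains unknown. On these data alone, whether an amine such as piperazine or a carboxylic acid there would move the number in this assay stays open.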